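Swapping a naphthyl group for an acetylphenyl group

The source may hold more compounds than are shown below. What is called first, only, known or untested is meant among the compounds shown, and "the series" means these compounds.

Measured compounds:
compound 1 `Brc1cn2ccnc2c(-c2ccc3ncn(C4CCCCC4)c3c2)n1`: 10.2%
compound 2 `COc1ccc(-c2cn3ccnc3c(-c3ccc4ncn(C5CCCCC5)c4c3)n2)cc1`: 62.2%
compound 3 `c1ccc2c(-c3cn4ccnc4c(-c4ccc5ncn(C6CCCCC6)c5c4)n3)cccc2c1`: 4.32%

In a functional assay on NCI-H23 cells (Homo sapiens) for inhibition, read by sulforhodamine B assay, with a stated time of 48 h, tested at 10 uM (a lower number here means less inhibition, a higher number more inhibition at the concentration tested (going by the name of the read-out)), compound 3 gives the lowest of the three numbers; compound 1 sits within the scatter of it, while compound 2 sits far above it. Compound 4 `CC(=O)c1ccc(-c2cn3ccnc3c(-c3ccc4ncn(C5CCCCC5)c4c3)n2)cc1` differs from compound 3 by 4-acetylphenyl in place of naphthalen-1-yl on an aromatic carbon. The step that bears on this is a number 57.9 percentage points lower from compound 2 to compound 3 (beyond the scatter), which shows that a 4-methoxyphenyl, another six-membered aromatic ring with one group in the para position, gives much more inhibition than naphthalen-1-yl at this place. The step of a number 52 percentage points higher from compound 1 to compound 2 (beyond the scatter) also shows the 4-methoxyphenyl group far above bromo. An increase is therefore expected, estimated as a number 40.7 percentage points higher from compound 3 to compound 4 (beyond the scatter). Compound 4 is expected to give about 45%, within a range from 15% to 75%.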

Compound 4, a percentage reported as inhibition, at one concentration (the size of the read-out at that concentration, not a potency): 8.6%
Compound 4: middle estimate off by 36.4 percentage points, on the high side; the measured number lies below the stated range.
By their numbers in this assay, from the lowest: compounds 3, 4 and 1 (each within the scatter of the next); then compound 2.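

In this assay, the 4-substituted phenyl ring does not bring inhibition by itself: acetyl in place of methoxy gives a number 53.6 percentage points lower from compound 2 to compound 4 (beyond the scatter), so the group on that ring matters greatly. The 4-acetylphenyl group also stays level with naphthalen-1-yl, at a number 4.3 percentage points higher from compound 3 to compound 4 (within the scatter), and with bromo, at a number 1.6 percentage points lower from compound 1 to compound 4 (within the scatter). Of the four groups at this position, only 4-methoxyphenyl stands apart. Nothing available explains the gap between methoxy and acetyl. Going by these compounds, whether an amine or a carboxylic acid on that ring would behave like methoxy or like acetyl remains open.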